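Swapping Hydroxy for Ethylsulfonylamino on the Shared Core

The source may hold more compounds than are shown below. What is called first, only, known or untested is meant among the compounds shown, and "the series" means these compounds.

Measured compounds:
compound 1, `Oc1cccc2c1CCCC2c1c[nH]cn1`: 30.9 nM
compound 2, `CS(=O)(=O)Nc1ccc(Cl)c2c1CCCC2c1c[nH]cn1`: 2880 nM

Both were tested in an assay on isolated protein for binding affinity to Alpha-1D adrenergic receptor (Rattus norvegicus), read by radioligand binding; a lower number here means a stronger inhibitor, a higher number a weaker inhibitor. Compound 1 stands at the lowest of the two numbers; compound 2 gives a far higher number, a gap well beyond the usual scatter. For the measured compounds named here, compound 2 differs from compound 1 in two places at once, so its two values show only that a sulfonylamino group together with a chloro substituent goes with much weaker binding.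

Compound 3, `CCS(=O)(=O)Nc1cccc2c1CCCC2c1c[nH]cn1`, has not yet been measured. It differs from compound 1 in one place: (ethylsulfonyl)amino in place of hydroxy on an aromatic carbon. Going by the values given here, no direct step for this change has been measured, but a weakening is expected, because compound 2 gives 2880 nM with a closely related sulfonylamino group. The step of a 19-fold higher number from compound 1 to compound 3 (1.29 log units; beyond the scatter) is expected to be large and toward a higher number. Compound 3 is estimated to give 600 nM, with a range from 100 nM to 4000 nM.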

Compound 3, inhibition constant: 1070 nM
The estimate for compound 3 lay 1.8-fold (0.25 log units) below the measured number, within the range that was stated.
By their numbers in this assay, from the lowest: compound 1; then compound 3; then compound 2.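

In this assay replacing hydroxy with (ethylsulfonyl)amino on this aromatic carbon gives a 35-fold higher number from compound 1 to compound 3 (1.54 log units; beyond the scatter), a large weakening. Compound 2 had changed in two places at once, so its number could not be tied to either change; this pair differs in one place only, and it shows that the swap on the shared core is enough on its own to weaken binding by a wide margin. Nothing measured here explains why binding weakens with this swap.

Still open, going by these compounds, is whether an amine, a methoxy group or an amide on this same carbon would stay closer to compound 1 or fall as far as compound 3. On these data alone, the separate contribution of the chloro substituent in compound 2 also remains unknown.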